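Paw edema series: methyl in place of chloro

This account rests on a few compounds, and the source may have more. Where it says the series, first, only, none or still open, it means among the compounds named here.

Compound 2 `NS(=O)(=O)c1sc(Cl)cc1-c1csc(-c2ccccc2COc2ccc(Cl)cc2)n1` gives 76.4% in a functional assay on the whole organism (strain Wistar albino) for inhibition, with Rattus norvegicus as the target, read by paw edema, at a dose of 10 mg/kg by the oral route; on this read-out lower numbers stand for less inhibition and higher numbers for more inhibition at the one dose given (going by the name of the read-out). Compound 1 `Cc1ccc(OCc2ccccc2-c2nc(-c3cc(Cl)sc3S(N)(=O)=O)cs2)cc1` gives 68.7%; the change methyl in place of chloro on an aromatic carbon made the step of a number 7.7 percentage points lower from compound 2 to compound 1 (within the scatter). Compound 3 `Clc1ccc(OCc2ccccc2-c2nc(-c3cccc(Br)c3)cs2)cc1` gives 42.9%, and its core differs from that of compound 2 by 3-bromophenyl in place of 5-chloro-2-sulfamoylthiophen-3-yl on an aromatic carbon, with the step of a number 33.5 percentage points lower from compound 2 to compound 3 (beyond the scatter). Compound 4 `Cc1ccc(OCc2ccccc2-c2nc(-c3cccc(Br)c3)cs2)cc1` has not been measured; it differs from compound 3 by methyl in place of chloro on an aromatic carbon, the same change as from compound 2 to compound 1, at the same place. What this change does on the core of compound 3 has not been seen. For compound 4 the step of a number 5.9 percentage points lower from compound 3 to compound 4 (within the scatter) is expected to be about as small as the earlier one, because that earlier step a number 7.7 percentage points lower from compound 2 to compound 1 (within the scatter) stays within the scatter. Compound 4 is therefore estimated at 37%, between 24% and 50%.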

Compound 4, a percentage reported as inhibition, in the whole organism at one dose (the size of the read-out at that dose, not a potency): 44.5%
The estimate for compound 4 lay 7.5 percentage points below the measured number; measured number inside the range.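

In this assay, methyl in place of chloro gives a number 1.6 percentage points higher from compound 3 to compound 4 (within the scatter), and this step agrees with the one on the other core: the same change on two cores in this assay, a number 7.7 percentage points lower (within the scatter) from compound 2 to compound 1 and a number 1.6 percentage points higher (within the scatter) from compound 3 to compound 4, 9.3 percentage points apart, within the scatter of two such steps
3-Bromophenyl in place of 5-chloro-2-sulfamoylthiophen-3-yl gives a number 24.2 percentage points lower from compound 1 to compound 4 (beyond the scatter), and this exchange likewise reads alike with methyl and with chloro on the phenoxy ring: the same change on two cores in this assay, a number 33.5 percentage points lower (beyond the scatter) from compound 2 to compound 3 and a number 24.2 percentage points lower (beyond the scatter) from compound 1 to compound 4, 9.3 percentage points apart, within the scatter of two such steps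
Across these two cores the methyl and chloro compounds are therefore not told apart at this one dose, but two pairs do not show that this holds on other cores, and they give no reason for it.

On these data alone, whether an amine or a methoxy group on that same aromatic carbon would also leave the read-out unmoved stays open. Also open, as far as these compounds go, is which part of 5-chloro-2-sulfamoylthiophen-3-yl carries the larger step, as the whole group changes at once.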